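Nucleoside analogues in a cell-based assay: one more variation

A few compounds are considered here, and "the series" means these few. Any claim that something is new, unique, unknown or untested is made for them only; others in the source may bear on it.

Measured compounds:
compound 1, `Cn1c(=O)n(C2OC(CO)[C@@H](O)[C@H]2O)c2nc(N)nc(O)c21`: 72%
compound 2, `NC(=O)Cn1c(=O)n(C2OC(CO)[C@@H](O)[C@H]2O)c2nc(N)nc(O)c21`: 42%

In a functional assay on YAC-1 cells (Mus musculus) (a lower number here means a smaller maximal response, a higher number a larger maximal response), compound 1 gives 72% and compound 2 gives 42%. Compound 2 thus stands lowest of the two measured values, with compound 1 above it by a gap that exceeds the usual scatter. The unmeasured compound 3, `Nc1nc(O)c2c(n1)n(C1OC(CO)[C@@H](O)[C@H]1O)c(=O)n2Cc1ccc([N+](=O)[O-])cc1`, differs from compound 2 in one place: 4-nitrophenyl in place of carbamoyl on a saturated chain carbon bound to an aromatic nitrogen. Among the measured compounds shown here, the only measured step at this place is a number 30 percentage points lower from compound 1 to compound 2 (beyond the scatter), where a carbamoyl group replaced a hydrogen. That step tells what entering a group at this carbon did once, but nothing about trading carbamoyl for 4-nitrophenyl, so guidance is thin. For the measured compounds named here, with no step that speaks directly to this exchange, the expectation for compound 3 is a number close to that of compound 2, the step of a number 3 percentage points higher from compound 2 to compound 3 (within the scatter) being expected to stay within the scatter. The estimate for compound 3 in this assay is therefore 45%, expected to lie between 20% and 75%.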

Compound 3, largest response reached (reported as maximal response), in percent of the reference or control that the assay uses: 50%
Compound 3: middle estimate off by 5 percentage points, on the low side, within the range that was stated.
By their numbers in this assay, from the lowest: compounds 2 and 3 (each within the scatter of the next); then compound 1.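

In this assay, the exchange of carbamoyl for 4-nitrophenyl on a saturated chain carbon bound to an aromatic nitrogen gives a number 8 percentage points higher from compound 2 to compound 3 (within the scatter), so two groups that share little, one with a six-membered aromatic ring and one with no ring, cannot be told apart here. Set against the hydrogen of compound 1, the same aromatic group gives a number 22 percentage points lower from compound 1 to compound 3 (beyond the scatter), so the fall seen with carbamoyl is now seen with a second, quite different group, and neither of the two substituted compounds goes against this. No measurement at hand explains either result.

Still open, from the compounds shown here alone, is whether any group at this carbon would give the same fall, or whether an amine or a carboxylic acid there would behave differently. A plain phenyl ring would show whether the nitro group of 4-nitrophenyl plays any part.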